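Furan to Thiophene: What to Expect for Compound 4

The compounds below may be only part of what the source reports. "The series", "measured", "known", "first", "only" and "open" are said of these compounds alone.

Measured so far:
- Compound 1, `S=C(N/N=C\c1ccc(Cl)cc1)NC1CCCCC1`, in a functional assay on MDA-MB-231 cells (Homo sapiens) for inhibition, read by WST assay, with a stated time of 48 h (a higher number here means a weaker inhibitor, a lower number a stronger inhibitor), gives 38300 nM.
- Compound 2, `CN(C)c1ccc(/C=N\NC(=S)NC2CCCCC2)cc1`, in this assay gives 125000 nM.
- Compound 3, `S=C(N/N=C\c1ccco1)NC1CCCCC1`, in this assay gives 141000 nM.

Compound 3 has the highest number of the three. Its gap to compound 2 lies within the scatter, so the two cannot be ranked against each other; its gap to compound 1 lies beyond the scatter, so compound 1 is the stronger inhibitor of that pair. Among the compounds with values here, the only single-point step among the measured compounds is a 3.3-fold higher number from compound 1 to compound 2 (0.51 log units; beyond the scatter), a change of a substituent on a six-membered aromatic ring.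

Compound 4, `S=C(N/N=C\c1cccs1)NC1CCCCC1`, differs from compound 3 by thiophen-2-yl in place of furan-2-yl on a carbon with a double bond to nitrogen. Within the data shown here, no measured step changes the five-membered ring itself, so the step from compound 1 to compound 2 offers no direct guide here. Without a precedent, the expected step of a 1.4-fold lower number from compound 3 to compound 4 (0.15 log units; within the scatter) is one within the scatter. Compound 4 is therefore estimated at 100000 nM, with a range of 40000 nM to 300000 nM.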

Compound 4, half-maximal inhibitory concentration: 58600 nM
For compound 4 the middle estimate is 1.7-fold (0.23 log units) above the measured one; low and high end bracket the measured number.
By their numbers in this assay, from the lowest: compounds 1 and 4 (each within the scatter of the next); then compounds 2 and 3 (each within the scatter of the next).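

Within the data shown here, replacing the five-membered ring itself is a kind of change the earlier compounds did not cover, and in this assay it gives a 2.4-fold lower number from compound 3 to compound 4 (0.38 log units; beyond the scatter) as a modest step. Furan-2-yl and thiophen-2-yl have the same count of heavy atoms and the same hydrogen-bond donor and acceptor counts, and they differ in one ring atom, oxygen or sulfur. So on this carbon with a double bond to nitrogen, exchanging that single atom is enough to move the number beyond the scatter, although no measurement here explains the step.

The compounds shown leave open whether a ring with nitrogen as its hetero atom, such as pyrrol-2-yl, would give a number like that of compound 3 or compound 4. They also leave open whether a methyl group on the thiophene ring would move the number further.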